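A Longer Alkyl on the Amine Nitrogen

The source may hold more compounds than are shown below. What is called first, only, known or untested is meant among the compounds shown, and "the series" means these compounds.

Compound 1 `CNCC(=O)N(C)CC(=O)Nc1nc2ccc(OC(F)(F)F)cc2s1` and compound 2 `CCNCC(=O)N(C)CC(=O)Nc1nc2ccc(OC(F)(F)F)cc2s1` share one core and differ only in a methyl in place of hydrogen on a saturated chain carbon bound to an amine nitrogen. In an ADME assay for pharmacokinetics, read by LC-MS, in simulated intestinal fluid, tested at 0.01 mg/mL (a lower number here means that the compound disappears faster, a higher number that the compound lasts longer), compound 1 gives < 1 h, which is a limit of the assay rather than a number. In this assay compound 2 likewise gives < 1 h, again a limit. The step that the two limits leave unreadable from compound 1 to compound 2 therefore cannot be read in size. Compound 3 `CC(C)NCC(=O)N(C)CC(=O)Nc1nc2ccc(OC(F)(F)F)cc2s1` carries the change (methyl in place of hydrogen on a saturated chain carbon bound to an amine nitrogen and a saturated chain carbon). Among the compounds with values here, the only measured step that bears on this change is the one just described, and it yields no size because the limit of < 1 h in this assay, at which 2 of the 2 values shown sit, shows where both values sit. With nothing in hand to suggest a longer half-life, compound 3 is expected to remain at the same limit, a step that the limit leaves unreadable from compound 2 to compound 3 that is not expected to exceed the scatter. Compound 3 is accordingly estimated at 0.5 h in this assay, between 0.15 h and 1.5 h, with the assay most likely again reporting only a limit.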

Compound 3, half-life: > 4 h
Compound 3: no number, only a limit; the forecaster's own chance of this, stated with the estimate: 80%; at least 8.0-fold (0.90 log units) between middle value and limit.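

In this assay, methyl in place of hydrogen on a saturated chain carbon bound to an amine nitrogen and a saturated chain carbon gives an at least 4.0-fold higher number from compound 2 to compound 3 (0.60 log units; beyond the scatter), and isopropyl in place of methyl on the amine nitrogen gives an at least 4.0-fold higher number from compound 1 to compound 3 (0.60 log units; beyond the scatter). Within the data shown here, the step between compound 1 and compound 2 cannot be read, so these are the first readable steps at this position, and they show that the half-life responds to the alkyl group on the amine nitrogen. Both steps run between limits of the assay rather than numbers, so they give only a minimum size: the limit of > 4 h in this assay, at which 1 of the 3 values shown sits.

The compounds shown leave open how long the half-life of compound 3 actually is, and whether the change depends on the branched isopropyl or would also appear with an unbranched chain. A propyl, cyclopropyl or tert-butyl group on the same amine nitrogen would bear on that question.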